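The source may report more compounds than this note shows. Statements on the series, on what has been measured and on what is new or still open speak of the compounds shown alone.

Compound 1 `N#Cc1c(N)nc(SCc2cnc[nH]2)c(C#N)c1-c1ccc(OCC2CC2)cc1`; in a functional assay on CHO cells for agonist activity at adenosine receptor A2b (Homo sapiens), read by AlphaScreen and cAMP accumulation (a lower number here means that less compound is needed, a higher number that more compound is needed for the effect), compound 1 gives 139 nM.
Compound 2 `N#Cc1c(N)nc(SCc2ncn[nH]2)c(C#N)c1-c1ccc(OCC2CC2)cc1`; in this assay compound 2 gives 51 nM.

Going by the values given here, compound 2 holds the lower of the two numbers, reached by the only measured step, a 2.7-fold lower number from compound 1 to compound 2 (0.44 log units; beyond the scatter), which exchanged one five-membered ring for another on a saturated chain carbon bound to a sulfur. Compound 3 `CNC(=O)CSc1nc(N)c(C#N)c(-c2ccc(OCC3CC3)cc2)c1C#N` departs from compound 2 by methylcarbamoyl in place of 1H-1,2,4-triazol-5-yl on a saturated chain carbon bound to a sulfur. Among the compounds with values here, no measured step covers replacing a ring with an open amide, so only the size of the earlier step offers a guide, not its direction. The expectation for compound 3 is a modest step, a 2.4-fold higher number from compound 2 to compound 3 (0.37 log units; beyond the scatter). Compound 3 is estimated at 120 nM, between 30 nM and 500 nM.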

Compound 3, half-maximal effective concentration: 94 nM
Beside the measured number, compound 3's estimate is 1.3-fold (0.11 log units) above it; low and high end bracket the measured number.
By their numbers in this assay, from the lowest: compounds 2, 3 and 1 (each within the scatter of the next, the first and the last beyond it).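

In this assay there is a 1.8-fold higher number from compound 2 to compound 3 (0.27 log units; within the scatter) and a 1.5-fold lower number from compound 1 to compound 3 (0.17 log units; within the scatter) on going to methylcarbamoyl on a saturated chain carbon bound to a sulfur. An open group with no ring therefore sits within the scatter of both compounds carrying a five-membered aromatic ring, so such a ring is not required at this position for numbers of this size. Nothing measured here explains this result.

On these data alone, how a carboxylic acid, an amine or a longer chain would read on this same carbon remains open.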